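The compounds below may be only part of what the source reports. "The series", "measured", "known", "first", "only" and "open" are said of these compounds alone.

Notes on the series built on the shared core of compound 1 `COc1ccc(-c2c(Nc3ccc(F)cc3)c3ccccc3oc2=O)cc1`. Among the compounds with values here, in a functional assay on HCT-116 cells (Homo sapiens) for antiproliferative activity, read by MTT assay, with a stated time of 48 h (on this read-out lower numbers stand for stronger inhibition and higher numbers for weaker inhibition), compound 1 gives 39400 nM, the second highest of the three numbers so far. Compound 3 `COc1ccc(-c2c(Nc3ccc(C)cc3)c3ccccc3oc2=O)cc1` gives 64800 nM; the step of a 1.6-fold higher number from compound 1 to compound 3 (0.22 log units; within the scatter) is within the scatter, so these two are not separated. Within the data shown here, compound 2 `COc1ccc(-c2c(Nc3ccc(C)c(O)c3)c3ccccc3oc2=O)cc1` gives 12300 nM, and the step of a 3.2-fold lower number from compound 1 to compound 2 (0.51 log units; beyond the scatter) lies beyond the scatter, as does a 5.3-fold higher number from compound 2 to compound 3 (0.72 log units; beyond the scatter), the one single-point change in the set that touches a hydroxy.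

Compound 4 `COc1ccc(-c2c(Nc3ccc(F)cc3)c3ccc(O)cc3oc2=O)cc1` departs from compound 1 by hydroxy in place of hydrogen on an aromatic carbon. Among the measured compounds shown here, no measured pair alters the core in this way; the only hydroxy step, a 5.3-fold higher number from compound 2 to compound 3 (0.72 log units; beyond the scatter), concerns the ring carried on the nitrogen, not the fused system of the core, so it bears on compound 4 only as a loose guide. It is read here as pointing toward a modest lowering, with wide uncertainty since the place differs. Compound 4 is therefore expected at 18000 nM, with a range of 6000 nM to 50000 nM. The step this implies, a 2.2-fold lower number from compound 1 to compound 4 (0.34 log units; beyond the scatter), is expected to be modest, toward a lower number, and could fall within the scatter.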

Compound 4, half-maximal inhibitory concentration: 66100 nM
Beside the measured number, compound 4's estimate is 3.7-fold (0.56 log units) below it, outside the stated range (above it).
By their numbers in this assay, from the lowest: compound 2; then compounds 1, 3 and 4 (each within the scatter of the next).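

In this assay, hydroxy in place of hydrogen on an aromatic carbon of the six-membered ring of carbon only, part of the fused system of two rings in the shared core, gives a 1.7-fold higher number from compound 1 to compound 4 (0.22 log units; within the scatter), so hydroxy and hydrogen are not separated at this place. Within the data shown here, this is the first reading of a change on that part of the core, and it adds a second hydroxy step to the one on the ring carried on the nitrogen. Within these compounds, the hydroxy change does not read the same in both places, and the step for compound 2 and compound 3 cannot be carried over to this position: the same change on two cores in this assay, a 5.3-fold higher number (0.72 log units; beyond the scatter) from compound 2 to compound 3 and a 1.7-fold lower number (0.22 log units; within the scatter) from compound 4 to compound 1, 8.8-fold (0.95 log units) apart, beyond the scatter of two such steps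

The compounds shown leave open whether another group at this place, such as an amine or a carboxylic acid, would separate from hydrogen, and whether hydroxy on the other aromatic carbons of the fused system would read as it does in compound 4. They also leave open how hydroxy at this place would read with the 3-hydroxy-4-methylphenyl ring of compound 2 on the nitrogen.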